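One Added Methyl on Compound 1

The compounds below may be only part of what the source reports. "The series", "measured", "known", "first", "only" and "open" are said of these compounds alone.

In a functional assay on P388 cells (Mus musculus) for cytotoxicity (on this read-out lower numbers stand for stronger inhibition and higher numbers for weaker inhibition), compound 1 `CC(C)=CCCC1=CCc2c(O)ccc(O)c2C1` gives 2100 nM and compound 2 `CC(=O)Oc1ccc(OC(C)=O)c2c1CC=C(CCC=C(C)C)C2` gives 1500 nM and these two numbers lie within the usual scatter of each other. Among the measured compounds shown here, compound 1 therefore stands level with the only other compound measured so far, and neither can be called the stronger. Compound 3 `CC(C)=CCCC1=CCc2c(O)cc(C)c(O)c2C1` keeps the core of compound 1 and differs in one place. It carries methyl in place of hydrogen on an aromatic carbon, ortho to a hydroxy group methyl in place of hydrogen on an aromatic carbon and the rest of the structure stays the same. For the measured compounds named here, no measured pair shows what this kind of change does here, so the expectation is cautious. The expected step of a 1.2-fold lower number from compound 1 to compound 3 (0.07 log units; within the scatter) in this assay is small and stays within the scatter, with no firm direction. Compound 3 is estimated at 1800 nM with a likely range from 600 nM to 5000 nM for repeated measurements.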

Compound 3, half-maximal inhibitory concentration: 3800 nM
The estimate for compound 3 lay 2.1-fold (0.32 log units) below the measured number; the range from low to high includes it.
By their numbers in this assay, from the lowest: compounds 2, 1 and 3 (each within the scatter of the next, the first and the last beyond it).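

Among the compounds shown here, this pair gives the first direct reading of what this change does here: in this assay, methyl in place of hydrogen on an aromatic carbon, ortho to a hydroxy group, gives a 1.8-fold higher number from compound 1 to compound 3 (0.26 log units; within the scatter) and so stays inside the ordinary spread of repeated measurements. This position on the core of compound 1 can therefore carry a methyl without a clear gain or loss on this read-out, although a single pair cannot establish a general rule. No measurement available here bears on the reason for this outcome.

On these data alone, it remains open whether an ethyl group, a longer chain or an amine on this same aromatic carbon would also leave the read-out within the scatter. As far as these compounds go, it is equally open whether methyl would behave the same way on the acetylated core of compound 2.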